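Sulfonyl substituent change on the piperidine carboxamide core

The source may report more compounds than this note shows. Statements on the series, on what has been measured and on what is new or still open speak of the compounds shown alone.

Measured so far:
compound 1 `O=C([C@@H]1CCCN(S(=O)(=O)c2ccc(S(=O)(=O)N3CC[C@@H](O)C3)cc2)C1)N1CCC(F)(F)CC1`: 210 nM
compound 2 `CCN(CC)S(=O)(=O)c1ccc(S(=O)(=O)N2CCC[C@@H](C(=O)NC3COC3)C2)cc1`: 2340 nM

In a functional assay on MIA PaCa-2 cells (Homo sapiens) for inhibition, read by MTT assay, with a stated time of 7 days (a lower number here means a stronger inhibitor, a higher number a weaker inhibitor), compound 1 gives the lowest number of the two compounds measured. Compound 2 differs from compound 1 in more than one place, and its number is higher by a margin beyond the scatter; with two changes at once, the comparison does not show which of them carries the loss.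

Compound 3 `O=C([C@@H]1CCCN(S(=O)(=O)c2ccc(S(=O)(=O)C3CC3)cc2)C1)N1CCC(F)(F)CC1` is the next compound to be measured. It keeps the core of compound 1 and changes one place: cyclopropyl in place of 3-hydroxypyrrolidin-1-yl on a sulfonyl sulfur. Among the compounds with values here, the group that leaves brings a hydrogen-bond donor and acceptor; the group that enters brings none, and no measured pair isolates this change.

For compound 3 a small step upward from compound 1 is expected, a 1.9-fold higher number from compound 1 to compound 3 (0.28 log units; within the scatter), at the edge of the scatter. The expected value for compound 3 in this assay is 400 nM, with a range from 150 nM to 1200 nM.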

Compound 3, half-maximal inhibitory concentration: 26 nM
Beside the measured number, compound 3's estimate is 15-fold (1.19 log units) above it; measured number outside the range, below it.
By their numbers in this assay, from the lowest: compound 3; then compound 1; then compound 2.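

In this assay, within the data shown here, replacing 3-hydroxypyrrolidin-1-yl with cyclopropyl on the sulfonyl sulfur gives an 8.1-fold lower number from compound 1 to compound 3 (0.91 log units; beyond the scatter), the first single-place comparison. At this position, the 3-hydroxypyrrolidin-1-yl group is therefore not required for a low number: cyclopropyl has fewer heavy atoms and none of the hydrogen-bond donors or acceptors of the group it replaces, yet the number falls. No measurement at hand bears on the reason for this fall.

This single change alters the ring, the attached atom and the hydroxyl group together, so the contribution of each remains unresolved; pyrrolidin-1-yl without the hydroxyl group, or methyl or cyclobutyl on the same sulfur, would help separate them. Going by these compounds, whether the step carries over when the group on the carbonyl differs also remains open.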